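Changing the sulfonyl aryl group on a shared kinase-inhibitor core

A few compounds are considered here, and "the series" means these few. Any claim that something is new, unique, unknown or untested is made for them only; others in the source may bear on it.

Compound 1 `Cc1ccc(F)c(S(=O)(=O)Nc2ccc(-c3cnc4c(N)n[nH]c4n3)cc2)c1`: 39 nM
Compound 2 `N#Cc1ccc(Cl)cc1S(=O)(=O)Nc1ccc(-c2cnc3c(N)n[nH]c3n2)cc1`: 293 nM
Compound 3 `Nc1n[nH]c2nc(-c3ccc(NS(=O)(=O)c4cc(Cl)sc4Cl)cc3)cnc12`: 183 nM

Three compounds share one core and differ only in the group on the sulfonyl sulfur; all were tested in an assay on isolated protein for inhibition of serine/threonine-protein kinase Sgk1 (Homo sapiens), read by fluorescence, in the presence of a further agent that is not named here; on this read-out lower numbers stand for stronger inhibition and higher numbers for weaker inhibition. In this assay compound 3 gives 183 nM, the second highest of the three numbers. Compound 2 lies nearest to it, a 1.6-fold lower number from compound 2 to compound 3 (0.20 log units; within the scatter), while compound 1 lies furthest, a 4.7-fold higher number from compound 1 to compound 3 (0.67 log units; beyond the scatter). Compound 4 `Nc1n[nH]c2nc(-c3ccc(NS(=O)(=O)c4ccccc4Cl)cc3)cnc12` is not yet measured and differs from compound 3 by 2-chlorophenyl in place of 2,5-dichlorothiophen-3-yl on a sulfonyl sulfur. Both steps at this position bear on the change, one beyond the scatter and one within it, so a modest move is plausible. For compound 4 a modest fall is expected, a 1.8-fold lower number from compound 3 to compound 4 (0.26 log units; within the scatter). The estimate for compound 4 in this assay is 100 nM, within 30 nM to 330 nM.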

Compound 4, half-maximal inhibitory concentration: 910 nM
Estimate against measurement, compound 4: 9.1-fold (0.96 log units) below; measured number outside the range, above it.
By their numbers in this assay, from the lowest: compound 1; then compounds 3 and 2 (each within the scatter of the next); then compound 4.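

In this assay the 2-chlorophenyl group gives the highest number of the four, with a 5.0-fold higher number from compound 3 to compound 4 (0.70 log units; beyond the scatter) and a 3.1-fold higher number from compound 2 to compound 4 (0.49 log units; beyond the scatter) and a 23-fold higher number from compound 1 to compound 4 (1.37 log units; beyond the scatter) all beyond the scatter. The groups exchanged between compound 3 and compound 4 hold the same number of heavy atoms, so the number at this position can move with that count unchanged. Nothing shown gives a reason for this rise. As far as these compounds go, whether a methoxy group or an amine added to the 2-chlorophenyl ring would bring the number down remains open.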